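Diethylamino in Place of Dimethylamino on an Inactive Urea

A few compounds are considered here, and "the series" means these few. Any claim that something is new, unique, unknown or untested is made for them only; others in the source may bear on it.

Compound 1, `CN(C)Cc1ccc2nc(NC(=O)NN=C(c3ccccn3)c3ccccn3)sc2c1`, was tested in a functional assay on MCF7 cells (Homo sapiens) for antiproliferative activity, read by CCK-8 assay, with a stated time of 24 h; a lower number here means a stronger inhibitor, a higher number a weaker inhibitor. In this assay compound 1 gives > 40000 nM, which is a limit of the assay rather than a number. Compound 2, `CN(C)Cc1ccc(NC(=O)NN=C(c2ccccn2)c2ccccn2)cc1`, shares the hydrazone urea with compound 1. In this assay compound 2 gives > 40000 nM, again a limit rather than a measured number. Compound 2 therefore stands at the limit of > 40000 nM in this assay, at which 2 of the 2 values shown sit, with no measurable activity to speak of. Compound 3, `CCN(CC)Cc1ccc(NC(=O)NN=C(c2ccccn2)c2ccccn2)cc1`, differs from compound 2 in one place only: diethylamino in place of dimethylamino on a saturated chain carbon bound to an aromatic carbon. Within the data shown here, no measured step between compounds of this kind is available, and the two values shown give no direction to follow. One expects a step that the limit leaves unreadable from compound 2 to compound 3, that is, nothing beyond the scatter. For compound 3 the estimate is 45000 nM, with a range of 15000 nM to 100000 nM, and the result is most likely to be reported again as a limit.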

Compound 3, half-maximal inhibitory concentration: > 40000 nM
Compound 3 ended at the assay's limit (the forecaster's own chance of this, stated with the estimate: 80%); the middle value is on the limit's open side.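

Among these compounds, compound 2 and compound 3 both stand at a limit of the assay rather than at a number, so no step between them can be read: the limit of > 40000 nM in this assay, at which 3 of the 3 values shown sit. The compounds shown leave open whether diethylamino in place of dimethylamino would change anything in a compound with a measurable value.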